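The source may report more compounds than this note shows. Statements on the series, on what has been measured and on what is new or still open speak of the compounds shown alone.

Measured in a functional assay on HeLa cells (Homo sapiens) for inhibition, read by MTT assay, with a stated time of 72 h; on this read-out higher numbers stand for weaker inhibition and lower numbers for stronger inhibition:
compound 1, `O=C(Nc1ccc(Nc2ncnc3[nH]ncc23)cc1)Nc1ccc(C(F)(F)F)cc1` — > 10000 nM
compound 2, `CC(NC(=O)Nc1ccc(Nc2ncnc3[nH]ncc23)cc1)c1ccccc1` — > 10000 nM

Compound 1 stands only at a limit of this assay; its value > 10000 nM is a limit, not a number. Compound 2 likewise sits at a limit, > 10000 nM. Among the compounds with values here, the one measured step, a step that the two limits leave unreadable from compound 1 to compound 2, exchanges the group on the amide-type nitrogen and is unreadable, since (the limit of > 10000 nM in this assay, at which 2 of the 2 values shown sit).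

Compound 3, `O=C(Nc1ccc(Oc2ncnc3[nH]ncc23)cc1)Nc1ccc(C(F)(F)F)cc1`, is not yet measured in this assay. It differs from compound 1 at the other end of the molecule: a group of 10 heavy atoms (5 carbon, 4 nitrogen, 1 oxygen; one five-membered aromatic ring with 2 hetero atoms, one six-membered aromatic ring with 2 hetero atoms) in place of a group of 10 heavy atoms (5 carbon, 5 nitrogen; one five-membered aromatic ring with 2 hetero atoms, one six-membered aromatic ring with 2 hetero atoms), on an aromatic carbon. Within the data shown here, no measured step touches this place, and the step that is measured gives no size, so nothing in the data allows a direction to be read for the change from compound 1 to compound 3.

With compound 1 at a limit and both shown values at that limit, compound 3 is expected to remain at or near the same limit, and the step that the limit leaves unreadable from compound 1 to compound 3 is estimated as no readable change. The estimate for compound 3 in this assay is 15000 nM, with a range from 3000 nM to 60000 nM.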

Compound 3, half-maximal inhibitory concentration: > 10000 nM
Compound 3: a limit, no number; the forecaster's own chance of this, stated with the estimate: 80%; the middle value lies beyond the limit too.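

In this assay compound 3 gives > 10000 nM as a limit and not a number. No new step can be read between compound 1 and compound 3, whose values are both limits: the limit of > 10000 nM in this assay, at which 3 of the 3 values shown sit.

The compounds shown leave open whether this assay gives a number rather than a limit for any compound of this series, and so how large either exchange is.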